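Swapping the quinolin-6-yl group on a weak inhibitor

The source may hold more compounds than are shown below. What is called first, only, known or untested is meant among the compounds shown, and "the series" means these compounds.

Measured in a functional assay on DU-145 cells (Homo sapiens) for inhibition, read by trypan blue exclusion, with a stated time of 72 h; a higher number here means a weaker inhibitor, a lower number a stronger inhibitor
Compound 1 `Cn1c(=O)c(S(=O)(=O)c2ccc(F)cc2F)cc2cnc(Nc3cccc4[nH]ccc34)nc21` gives 750 nM
Compound 2 `Cn1c(=O)c(S(=O)(=O)c2ccccc2)cc2cnc(Nc3ccc4ncccc4c3)nc21` gives 50000 nM

Compound 2 has the higher number of the two, so it is the weaker inhibitor, and the gap lies beyond the scatter. Compound 3 `Cn1c(=O)c(S(=O)(=O)c2ccccc2)cc2cnc(Nc3cnc4[nH]ccc4c3)nc21` has not been measured yet. Its change is a group of 9 heavy atoms (7 carbon, 2 nitrogen; one five-membered aromatic ring with 1 hetero atom, one six-membered aromatic ring with 1 hetero atom) in place of a group of 10 heavy atoms (9 carbon, 1 nitrogen; one six-membered aromatic ring of carbon only, one six-membered aromatic ring with 1 hetero atom), on a nitrogen on an aromatic ring and quinolin-6-yl leaves. Within the data shown here, the only hint is compound 1 at 750 nM which also holds a five-membered aromatic ring in that place yet differs elsewhere too. The expected change is an 8.3-fold lower number from compound 2 to compound 3 (0.92 log units; beyond the scatter) in this assay toward a stronger inhibitor, beyond the scatter. The estimated value for compound 3 is 6000 nM with an expected range from 1000 nM to 35000 nM in this assay once it is measured.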

Compound 3, half-maximal inhibitory concentration: 1000 nM
Compound 3: the middle estimate sits 6.0-fold (0.78 log units) above what was measured; low and high end bracket the measured number.
By their numbers in this assay, from the lowest: compounds 1 and 3 (each within the scatter of the next); then compound 2.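

On a nitrogen on an aromatic ring, putting the new two-ring group in place of quinolin-6-yl gives a 50-fold lower number from compound 2 to compound 3 (1.70 log units; beyond the scatter) in this assay and so shows that this position strongly affects the read-out. A five-membered aromatic ring and a hydrogen-bond donor enter together in this single step, so it cannot show which of them matters. No available evidence explains the change. On these data alone, whether a phenyl or pyridin-3-yl group in that place would give a similarly low number remains open.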